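A few compounds are considered here, and "the series" means these few. Any claim that something is new, unique, unknown or untested is made for them only; others in the source may bear on it.

Measured so far:
- compound 1 `CC(C)CCn1c(=O)c(C2=NS(=O)(=O)c3cc(NS(C)(=O)=O)ccc3N2)c(O)n2ncnc12` — a limit in an ADME assay on Huh-7 cells (Homo sapiens) for cytotoxicity; a higher number here means that more compound is tolerated, a lower number that less compound is tolerated: > 100000 nM
- compound 2 `CS(=O)(=O)Nc1ccc2c(c1)S(=O)(=O)N=C(c1c(O)n3nccc3n(Cc3ccccc3)c1=O)N2` — again only a limit in this assay: > 100000 nM

For the measured compounds named here, compound 2 thus stands at the limit of this assay, not at a number, and the one other value shown sits at the same limit (the limit of > 100000 nM in this assay, at which 2 of the 2 values shown sit). Compound 3 `CS(=O)(=O)Nc1ccc2c(c1)S(=O)(=O)N=C(c1c(O)n3nccc3n(Cc3ccc(F)cc3)c1=O)N2` differs from compound 2 by fluoro in place of hydrogen on an aromatic carbon. Going by the values given here, no step between measured compounds is available here; the expected step from compound 2 to compound 3 in this assay is a step that the limit leaves unreadable from compound 2 to compound 3, none beyond the scatter. Compound 3 is therefore estimated at 150000 nM, between 60000 nM and 400000 nM, most likely reported again only as a limit.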

Compound 3, half-maximal cytotoxic concentration: > 100000 nM
Compound 3 was reported as a limit (the forecaster's own chance of this, stated with the estimate: 85%); the middle value does not contradict the limit.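

Compound 2 and compound 3 are both reported only as limits in this assay, so no step from benzyl to 4-fluorobenzyl can be read: the limit of > 100000 nM in this assay, at which 3 of the 3 values shown sit.

The compounds shown leave open where any actual value lies in this assay, and whether fluoro in place of hydrogen changes it.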